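A few compounds are considered here, and "the series" means these few. Any claim that something is new, unique, unknown or untested is made for them only; others in the source may bear on it.

Compound 1, `CC1(C)CCc2c([C@@H]3CCc4ccc(O)cc4O3)ccc(O)c2O1`, gives 44700 nM in a functional assay on Hep 3B2 cells (Homo sapiens) for cytotoxicity, read by MTT assay; on this read-out higher numbers stand for weaker inhibition and lower numbers for stronger inhibition. Compound 2, `CC1(C)C=Cc2c([C@H]3CCc4ccc(O)cc4O3)ccc(O)c2O1`, gives 63600 nM in this assay, and these two values lie within the usual scatter of each other, so neither compound can be placed above the other. Compound 3, `CC1(C)C=Cc2c([C@@H]3CCc4ccc(O)cc4O3)ccc(O)c2O1`, has not yet been measured. It differs from compound 2 in one way only: the two compounds have the same atoms and bonds and differ only in configuration as drawn: 1 of 1 stereo elements differ; a stereocentre at a saturated ring carbon is drawn R in compound 2 and S in compound 3. Within the data shown here, no measured pair shows what such a change alone does here, so the expected step is a 1.1-fold lower number from compound 2 to compound 3 (0.03 log units; within the scatter), nothing beyond the scatter. Compound 3 is therefore expected to give about 60000 nM, within a range of 25000 nM to 150000 nM.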

Compound 3, half-maximal inhibitory concentration: 75700 nM
The estimate for compound 3 lay 1.3-fold (0.10 log units) below the measured number; measured number inside the range.
By their numbers in this assay, from the lowest: compounds 1, 2 and 3 (each within the scatter of the next).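

In this assay, the inversion of the stereocentre at the saturated ring carbon gives a 1.2-fold higher number from compound 2 to compound 3 (0.08 log units; within the scatter), so the two drawn configurations cannot be told apart by their numbers. Among these compounds, this is the first pair to test this change alone, and any difference between these two compounds can come from one source only: the fact that compounds 2 and 3 differ only in the configuration as drawn. Still open, from the compounds shown here alone, is whether an amine or a carboxylic acid on the shared core, in place of a hydroxyl group, would shift the number beyond the scatter. Whether inversion behaves the same way in the core of compound 1 is also unknown.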